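Amide aryl swap on a pyrazole carboxamide series

The source may hold more compounds than are shown below. What is called first, only, known or untested is meant among the compounds shown, and "the series" means these compounds.

Compound 1, `Cc1c(C(=O)Nc2ccc(OC(F)(F)F)cc2)cnn1-c1ccc(F)cc1`, gives 3400 nM in a functional assay with Homo sapiens as the target; a lower number here means a stronger inhibitor, a higher number a weaker inhibitor. Compound 2, `COc1cccc(NC(=O)c2cnn(-c3ccc(F)cc3)c2C)c1`, gives 3700 nM in this assay. Compound 3, `Cc1c(C(=O)Nc2cccc(C(F)(F)F)c2)cnn1-c1ccc(F)cc1`, gives 1700 nM in this assay.

Compound 2 carries the highest number of the three in this assay. Compound 1 sits within the scatter of it, so the two cannot be ordered. Compound 3 stands apart: a 2.2-fold lower number from compound 2 to compound 3 (0.34 log units; beyond the scatter) is a modest step and lies beyond the scatter.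

The step to the unmeasured compound 4, `Cc1ccccc1NC(=O)c1cnn(-c2ccc(F)cc2)c1C`, is 2-methylphenyl in place of 3-methoxyphenyl on an amide-type nitrogen. Among the measured compounds shown here, no measured step matches this change. For the measured compounds named here, the only step at this amide-type nitrogen exchanges one group for another of a different name, and its size, a 2.2-fold lower number from compound 2 to compound 3 (0.34 log units; beyond the scatter), gives a rough measure of what a change on this ring has done so far. With no closer comparison, a step of similar or smaller size in either direction, or none beyond the scatter, is the expectation in this assay.

Compound 4 is therefore expected at 4000 nM, with a range of 1800 nM to 9000 nM. The expected step, a 1.1-fold higher number from compound 2 to compound 4 (0.03 log units; within the scatter), is estimated to stay within the scatter.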

Compound 4, half-maximal inhibitory concentration: 1100 nM
Compound 4: the middle estimate sits 3.6-fold (0.56 log units) above what was measured; measured number outside the range, below it.
By their numbers in this assay, from the lowest: compounds 4, 3, 1 and 2 (each within the scatter of the next, the first and the last beyond it).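

At the amide-type nitrogen, 2-methylphenyl in place of 3-methoxyphenyl gives a 3.4-fold lower number from compound 2 to compound 4 (0.53 log units; beyond the scatter) in this assay, showing that the 3-methoxyphenyl group of compound 2 is not needed for activity here: the entering group, with no hydrogen-bond acceptor, carries a lower number. Together with a 2.2-fold lower number from compound 2 to compound 3 (0.34 log units; beyond the scatter), this makes two different aryl groups at this nitrogen that beat 3-methoxyphenyl beyond the scatter, although compound 3 and compound 4 cannot be ordered against each other. No measurement among these compounds offers an explanation for the gain.

The compounds shown do not separate the change of methoxy to methyl from the change in its ring position, which 3-methylphenyl or 2-methoxyphenyl could settle. Going by these compounds, how an amine or a carboxylic acid on this ring would fare also remains open.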